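Swapping the Nitrogen Substituent: Cyclopropyl to Isobutyl

A few compounds are considered here, and "the series" means these few. Any claim that something is new, unique, unknown or untested is made for them only; others in the source may bear on it.

Compound 1 `CCC(CC)n1c(-c2ccc(OCc3c(-c4c(Cl)cccc4Cl)noc3C(C)C)cc2)nc2ccc(C(=O)O)cc21` gives 5690 nM in an assay on HEK-293T cells for antagonist activity at vitamin D3 receptor (Homo sapiens), read by a luciferase reporter, with a stated time of 24 h; a higher number here means a weaker inhibitor, a lower number a stronger inhibitor.
Compound 2 `CC(C)c1onc(-c2c(Cl)cccc2Cl)c1COc1ccc(-c2nc3ccc(C(=O)O)cc3n2C2CC2)cc1` gives 3200 nM in this assay.

Of the compounds shown here, two have been measured so far, and both share the same core; they differ only in the group carried on an aromatic nitrogen. Among the measured compounds shown here, compound 2 has the lower of the two numbers, but its only neighbour is compound 1, and the step of a 1.8-fold lower number from compound 1 to compound 2 (0.25 log units; within the scatter) does not set the two apart with any confidence. On the numbers shown, compound 2 cannot be called the more potent of the pair.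

Compound 3 `CC(C)Cn1c(-c2ccc(OCc3c(-c4c(Cl)cccc4Cl)noc3C(C)C)cc2)nc2ccc(C(=O)O)cc21` has not yet been measured. It differs from compound 2 as follows: isobutyl in place of cyclopropyl on an aromatic nitrogen. For the measured compounds named here, the only measured step that bears on this position, a 1.8-fold lower number from compound 1 to compound 2 (0.25 log units; within the scatter), exchanged one hydrocarbon group for another and stayed within the scatter. With isobutyl lying between cyclopropyl and pentan-3-yl in size, no step beyond the scatter is expected here either, so a 1.3-fold higher number from compound 2 to compound 3 (0.10 log units; within the scatter) is the expected change. Compound 3 is therefore estimated at 4000 nM in this assay, with a range from 1500 nM to 10000 nM.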

Compound 3, half-maximal inhibitory concentration: 1180 nM
Compound 3: the middle estimate sits 3.4-fold (0.53 log units) above what was measured, outside the stated range (below it).
By their numbers in this assay, from the lowest: compound 3; then compounds 2 and 1 (each within the scatter of the next).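

The earlier pair suggested that exchanging one hydrocarbon group for another on this aromatic nitrogen changes little in this assay, but this result shows that the choice of group can move the number beyond the scatter: isobutyl in place of cyclopropyl gives a 2.7-fold lower number from compound 2 to compound 3 (0.43 log units; beyond the scatter), and isobutyl in place of pentan-3-yl gives a 4.8-fold lower number from compound 1 to compound 3 (0.68 log units; beyond the scatter). Compound 3 can therefore be called the most potent of the three, even though compounds 1 and 2 remain within the scatter of each other, and the three-membered ring of cyclopropyl is clearly not needed to reach this level, since the open-chain isobutyl group does better. Nothing in the available data explains why isobutyl gives the lowest number of these three groups.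

On these data alone, it remains open whether the gain belongs to the branched shape of isobutyl or would also appear with a straight butyl chain, a cyclobutylmethyl group or a neopentyl group. The compounds shown also cannot tell whether a group carrying an ether oxygen or an amine would be tolerated at this position.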